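Swapping a Pyridine for a Phenyl Ring

The source may hold more compounds than are shown below. What is called first, only, known or untested is meant among the compounds shown, and "the series" means these compounds.

Compound 1 `O=C(CN1CCN(c2nnc(Cc3ccncc3)c3ccccc23)CC1)Nc1ccc(F)c(Cl)c1` was tested in a functional assay on A549 cells (Homo sapiens) for cytotoxicity, read by MTT assay, with a stated time of 72 h (a lower number here means a stronger inhibitor, a higher number a weaker inhibitor), and gave 12300 nM. Of the two compounds with a reported number it has the higher one, so it is the weaker inhibitor: compound 3 `O=C(CN1CCN(c2nnc(Cc3ccccc3)c3ccccc23)CC1)Nc1ccc(F)c(C(F)(F)F)c1` gives 2480 nM, a gap beyond the usual scatter. Compound 2 `COc1ccc(NC(=O)CN2CCN(c3nnc(Cc4ccccc4)c4ccccc34)CC2)cc1OC` is reported in this assay as "not active" (no number reported), with no number. Compound 4 `O=C(CN1CCN(c2nnc(Cc3ccccc3)c3ccccc23)CC1)Nc1ccc(F)c(Cl)c1` differs from compound 1 in one place: phenyl in place of pyridin-4-yl on a saturated chain carbon bound to an aromatic carbon. Compounds 2 and 3 already carry this phenyl, and their results range from no activity to the lowest number seen, so the phenyl by itself settles little. The step of a 2.1-fold lower number from compound 1 to compound 4 (0.31 log units; beyond the scatter) is expected to be modest and toward a lower number. Compound 4 is therefore estimated at 6000 nM, within 2000 nM to 20000 nM.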

Compound 4, half-maximal inhibitory concentration: "not active" (no number reported)
Compound 4: no number reported; the estimate stays without a comparison.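

For the compounds shown here, compound 4 is reported as "not active" without a number, so no step from compound 1 to compound 4 can be read. How far phenyl in place of pyridin-4-yl shifts the result in this assay stays open, and nothing shown here explains this outcome.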